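The source may report more compounds than this note shows. Statements on the series, on what has been measured and on what is new or still open speak of the compounds shown alone.

Measured compounds:
compound 1 `CS(=O)(=O)c1ccc(C(=O)NCCC(=O)N2CCCc3ccccc32)cc1[N+](=O)[O-]` — 10500 nM
compound 2 `CN(CC(=O)N1CCN(c2ccc(F)cc2)CC1)C(=O)c1ccc(S(C)(=O)=O)c([N+](=O)[O-])c1` — 17200 nM

In an ADME assay on HepG2 cells (Homo sapiens) for cytotoxicity, read by CellTiter-Glo and ATP content, with a stated time of 72 h (a higher number here means that more compound is needed for the effect, a lower number that less compound is needed), compound 1 gives 10500 nM, the lower of the two numbers; compound 2 gives 17200 nM, and the two lie within the scatter of each other. Compound 3 `CC1CCN(C(=O)CCNC(=O)c2ccc(S(C)(=O)=O)c([N+](=O)[O-])c2)CC1` has not yet been run in this assay. It differs from compound 1 in one place: 4-methylpiperidin-1-yl in place of 1,2,3,4-tetrahydroquinolin-1-yl on a carbonyl carbon. Going by the values given here, no step between measured compounds covers a change of this kind, so the step from compound 1 to compound 3 is expected to stay within the scatter, a 1.2-fold higher number from compound 1 to compound 3 (0.09 log units; within the scatter). Compound 3 is therefore estimated at 13000 nM, with a range from 5000 nM to 35000 nM.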

Compound 3, half-maximal effective concentration: > 27000 nM
Compound 3 gave a limit, no number; the forecaster's own chance of this, stated with the estimate: 20%; at least 2.0-fold (0.31 log units) between middle value and limit.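

In this assay, putting 4-methylpiperidin-1-yl in place of 1,2,3,4-tetrahydroquinolin-1-yl on a carbonyl carbon gives an at least 2.5-fold higher number from compound 1 to compound 3 (0.41 log units; beyond the scatter). Going by these compounds alone, the earlier compounds offered no step at this place, so this is the first sign that the group on this carbonyl carbon can move the number beyond the scatter. The result for compound 3 is a limit, not a number: the limit of > 27000 nM in this assay, at which 1 of the 3 values shown sits.

As far as these compounds go, the true size of the step remains open. So does whether the aromatic ring that leaves or the methyl that enters matters more, a question that an unsubstituted piperidin-1-yl at the same place could help to separate.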